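The compounds below may be only part of what the source reports. "The series", "measured", "known", "first", "only" and "open" are said of these compounds alone.

For the measured compounds named here, compound 2 `O=S(=O)(Nc1ccc(Cl)c(F)c1)c1ccc(-c2cnc(C3CC3)o2)cc1` stands lowest of the two numbers so far in a functional assay on cells (leukaemia cell line, Homo sapiens) for inhibition, read by sulforhodamine B assay, with a stated time of 48 h (a higher number here means a weaker inhibitor of growth, a lower number a stronger inhibitor of growth), giving 380 nM; compound 1 `O=S(=O)(Nc1ccc(Cl)cc1Cl)c1ccc(-c2cnc(C3CC3)o2)cc1` gives 481 nM, a gap within the scatter. Going by the values given here, the single measured step, a 1.3-fold lower number from compound 1 to compound 2 (0.10 log units; within the scatter), was also an exchange on the sulfonamide nitrogen and stayed within the scatter. Compound 3 `O=S(=O)(Nc1ccc(Br)c(Cl)c1)c1ccc(-c2cnc(C3CC3)o2)cc1` carries 4-bromo-3-chlorophenyl in place of 4-chloro-3-fluorophenyl on a sulfonamide nitrogen. Among the compounds with values here, because the only comparable exchange, a 1.3-fold lower number from compound 1 to compound 2 (0.10 log units; within the scatter), produced no step beyond the scatter, compound 3 is expected to sit close to compound 2, no change at the digits printed from compound 2 to compound 3 (within the scatter), with an estimate of 380 nM and a range of 170 nM to 850 nM.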

Compound 3, concentration for 50% growth inhibition: 491 nM
Estimate against measurement, compound 3: 1.3-fold (0.11 log units) below; the range from low to high includes it.
By their numbers in this assay, from the lowest: compounds 2, 1 and 3 (each within the scatter of the next).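

In this assay, putting 4-bromo-3-chlorophenyl in place of 4-chloro-3-fluorophenyl on the sulfonamide nitrogen gave a 1.3-fold higher number from compound 2 to compound 3 (0.11 log units; within the scatter) and the same group in place of 2,4-dichlorophenyl gave a 1.0-fold higher number from compound 1 to compound 3 (0.01 log units; within the scatter) in this read-out. Among these three compounds, the halogen-substituted phenyl groups at this position, now including one carrying bromine, read alike, with no step beyond the scatter. Nothing measured here gives a reason for this. Still open, as far as these compounds go, is whether a phenyl carrying an amine or a carboxylic acid, or a cyclohexyl group in place of the phenyl, would move the number beyond the scatter.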